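The compounds below may be only part of what the source reports. "The series", "measured", "known", "first", "only" and "open" are said of these compounds alone.

Of the compounds shown here, three of a shared core have already been tested. Compound 1 `O=C(Nc1ccc(Cl)cn1)C1CCCN(C(=O)c2cc(C(F)(F)F)cc(C(F)(F)F)c2)C1` gives in an ADME assay on PC-3 cells (Homo sapiens) for cytotoxicity, read by WST assay, tested at 100 uM (on this read-out higher numbers stand for more inhibition at the one concentration tested (going by the name of the read-out) and lower numbers for less inhibition), a reading of 0%. Compound 2 `CS(=O)(=O)c1cccc(C(=O)N2CCCC(C(=O)Nc3ccc(Cl)cc3)C2)c1` gives 2% in this assay, and compound 3 `CC(=O)Nc1cccc(C(=O)N2CCCC(C(=O)Nc3ccc(Cl)cc3)C2)c1` gives 4% in this assay. Compound 1 thus stands among three numbers that all lie within the usual scatter of one another, so none of the three can be told apart from the others. Within the data shown here, the one step that can be followed, a number 2 percentage points higher from compound 2 to compound 3 (within the scatter), changes an acetamido for a methylsulfonyl on an aromatic carbon and stays within the scatter.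

Compound 4 `CSc1cccc(NC(=O)C2CCCN(C(=O)c3cc(C(F)(F)F)cc(C(F)(F)F)c3)C2)c1` is not yet measured. It differs from compound 1 in that (3-(methylsulfanyl)phenyl in place of 5-chloropyridin-2-yl on an amide-type nitrogen). Among the measured compounds shown here, no measured step touches the group on the amide-type nitrogen, so nothing directly bears on this change; the only known step, at another place, was flat, and every measured number sits near the bottom of the scale. The expectation is therefore a step of a number 3 percentage points higher from compound 1 to compound 4 (within the scatter) with no movement beyond the scatter. Compound 4 is estimated at 3%, with a range from 0% to 14%.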

Compound 4, a percentage reported as inhibition, at one concentration (the size of the read-out at that concentration, not a potency): 0%
The estimate for compound 4 lay 3 percentage points above the measured number, within the range that was stated.
By their numbers in this assay, from the lowest: compounds 1, 4, 2 and 3 (each within the scatter of the next).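

In this assay, among these compounds, the result shows no change at the digits printed from compound 1 to compound 4 (within the scatter) when 3-(methylsulfanyl)phenyl replaces 5-chloropyridin-2-yl on an amide-type nitrogen, and this is the first step measured at this position. For this one pair, a carbon-only aromatic ring carrying a sulfur group reads the same as an aromatic ring with one hetero atom carrying a chlorine, though both readings lie near the bottom of the scale, where a flat step says little about how much this position can matter. Nothing measured here offers an explanation for this flat step.

Going by these compounds, whether any group on this nitrogen can move the reading beyond the scatter remains open. An open-chain alkyl group, a ring bearing a carboxylic acid or one bearing an amine would each test this position with a different kind of group.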